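This account rests on a few compounds, and the source may have more. Where it says the series, first, only, none or still open, it means among the compounds named here.

Working notes on the series. In a functional assay on CHO cells for agonist activity at Free fatty acid receptor 3 (Homo sapiens), read by calcium flux (on this read-out higher numbers stand for an effect only at larger amounts of compound and lower numbers for an effect already at smaller amounts), compound 1 `Cc1cccc(-c2cccc(NC(=O)c3nnc(CCC(=O)O)s3)c2)c1` gives > 10000 nM, which is a limit of the assay and not a number. In this assay compound 2 `O=C(O)CCc1ccc(OCc2nnc(C(=O)Nc3ccccc3F)s2)cc1` gives > 10000 nM, likewise a limit. Both values shown sit at that limit (the limit of > 10000 nM in this assay, at which 2 of the 2 values shown sit), so compound 2 stands at the edge of what the assay reports, with no number of its own beneath it and nothing in the set to rank it against.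

Compound 3 `O=C(O)CCc1ccc(OCc2nnc(C(=O)Nc3ccc(F)c(F)c3)s2)cc1` differs from compound 2 in one place: 3,4-difluorophenyl in place of 2-fluorophenyl on an amide-type nitrogen. Going by the values given here, no step between two measured compounds that differ in a single place exists here, so the size of this step is not anchored by any measurement. Because compound 2 gives only the limit > 10000 nM, the expectation is that the change moves nothing beyond the scatter; the expected step is a step that the limit leaves unreadable from compound 2 to compound 3. Compound 3 is estimated at 15000 nM, within 5000 nM to 50000 nM, most likely reported again as a limit.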

Compound 3, half-maximal effective concentration: > 10000 nM
Compound 3 ended at the assay's limit; the forecaster's own chance of this, stated with the estimate: 80%; the middle value does not contradict the limit.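

In this assay compound 3 gives > 10000 nM, a limit and not a number. No step can be read between compound 2 and compound 3 because both stand at a limit: the limit of > 10000 nM in this assay, at which 3 of the 3 values shown sit.

The compounds shown leave open which change to the series, if any, would give a readable value in this assay.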